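Notes on the ether-linked aryl ring: compound 3 to compound 4

The source may report more compounds than this note shows. Statements on the series, on what has been measured and on what is new or still open speak of the compounds shown alone.

Three compounds share one core and differ only in the aryl group carried on the saturated chain carbon bound to the ring oxygen. In an assay on lysate for inhibition of phosphatidylcholine:ceramide cholinephosphotransferase 2 (Homo sapiens), read by HPLC, with stated times of 30 min and 2 h (on this read-out lower numbers stand for stronger inhibition and higher numbers for weaker inhibition), compound 1 `O=C(Nc1cccnc1)c1ccccc1OCc1cccc(F)c1` gives 1600 nM and compound 2 `O=C(Nc1cccnc1)c1ccccc1OCc1cccc(Cl)c1` gives 1400 nM; a 1.1-fold lower number from compound 1 to compound 2 (0.06 log units; within the scatter). Compound 3 `Cc1c(Cl)cccc1COc1ccccc1C(=O)Nc1cccnc1` gives 3800 nM in this assay, the highest of the three numbers: a 2.4-fold higher number from compound 1 to compound 3 (0.38 log units; beyond the scatter) and a 2.7-fold higher number from compound 2 to compound 3 (0.43 log units; beyond the scatter).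

Compound 4 `Cc1cccc(C)c1COc1ccccc1C(=O)Nc1cccnc1` is not yet measured. The change from compound 3 is 2,6-dimethylphenyl in place of 3-chloro-2-methylphenyl on a saturated chain carbon bound to an oxygen on an aromatic ring. Among the measured compounds shown here, two measured steps bear on it only in part: the step from compound 1 to compound 2 shows that exchanging one halogen for another moved nothing beyond the scatter, while the step from compound 2 to compound 3 shows that a second substituent, a methyl, carried a modest rise. Compound 4 keeps two substituents on the ring, so a number near that of compound 3 is expected, with the exchange of chloro for methyl judged too weak on present evidence to predict a step beyond the scatter in either direction.

Compound 4 is estimated at 4500 nM in this assay. That estimate means a step of a 1.2-fold higher number from compound 3 to compound 4 (0.07 log units; within the scatter). The expected range for compound 4 runs from 1800 nM to 11000 nM.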

Compound 4, half-maximal inhibitory concentration: 890 nM
Compound 4: middle estimate off by 5.1-fold (0.70 log units), on the high side, outside the stated range (below it).
By their numbers in this assay, from the lowest: compounds 4, 2 and 1 (each within the scatter of the next); then compound 3.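

In this assay, the change to the 2,6-dimethylphenyl group removes the rise seen with the 3-chloro-2-methylphenyl group (a 4.3-fold lower number from compound 3 to compound 4 (0.63 log units; beyond the scatter)), so carrying two substituents on this aryl ring does not by itself go with a higher number. The steps to compound 4 from the rings with a single halogen stay within the scatter (a 1.6-fold lower number from compound 2 to compound 4 (0.20 log units; within the scatter); a 1.8-fold lower number from compound 1 to compound 4 (0.25 log units; within the scatter)), which leaves compound 3 as the only one of the four set apart, and compound 4 goes against reading the earlier methyl step (a 2.7-fold higher number from compound 2 to compound 3 (0.43 log units; beyond the scatter)) as a general effect of adding a methyl at this position. No evidence accompanies these numbers that would explain the difference between the two rings with two substituents.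

Open, on these data alone, is whether the higher number of compound 3 follows the chloro group itself or the particular arrangement of groups on its ring, and how a 2-methylphenyl group with no second substituent would compare. Also open, as far as these compounds go, is how a methoxy group or a carboxylic acid on this aryl ring, or a longer chain in place of the saturated chain carbon bound to the oxygen, would read on the shared core.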